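Replacing pyridin-3-yl with 3-aminophenyl on the shared core

The source may report more compounds than this note shows. Statements on the series, on what has been measured and on what is new or still open speak of the compounds shown alone.

Measured in a functional assay on HL-60 cells (Homo sapiens) for cytotoxicity, read by CellTiter-Blue, with a stated time of 48 h; on this read-out higher numbers stand for weaker inhibition and lower numbers for stronger inhibition:
- Compound 1 `CCOC(=O)CC1C(C(=O)OCC)=C(N)Oc2ccc(-c3cc(F)cc(F)c3)cc21`: 35900 nM
- Compound 2 `CCOC(=O)CC1C(C(=O)OCC)=C(N)Oc2ccc(-c3ccco3)cc21`: > 80000 nM, a limit of the assay
- Compound 3 `CCOC(=O)CC1C(C(=O)OCC)=C(N)Oc2ccc(-c3cccnc3)cc21`: 21500 nM

Compound 3 stands level with compound 1, as the gap between these two numbers, a 1.7-fold lower number from compound 1 to compound 3 (0.22 log units; within the scatter), shows. Compound 2 has only a limit, not a number. Measured against that limit, an at least 2.2-fold higher number from compound 1 to compound 2 (0.34 log units; beyond the scatter) and an at least 3.7-fold lower number from compound 2 to compound 3 (0.57 log units; beyond the scatter) both go beyond the scatter, and both involve furan-2-yl.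

Compound 4 `CCOC(=O)CC1C(C(=O)OCC)=C(N)Oc2ccc(-c3cccc(N)c3)cc21` carries 3-aminophenyl in place of pyridin-3-yl on an aromatic carbon. Its new group is a six-membered aromatic ring, as are the groups of compound 1 and compound 3. Among the compounds with values here, the one measured step between such groups, a 1.7-fold lower number from compound 1 to compound 3 (0.22 log units; within the scatter), therefore serves as the closest guide, and no change beyond the scatter is expected in this assay. The estimated step is a 1.4-fold higher number from compound 3 to compound 4 (0.14 log units; within the scatter). For compound 4 the estimated value is 30000 nM, with an expected range from 13000 nM to 70000 nM.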

Compound 4, half-maximal inhibitory concentration: 20200 nM
Compound 4: middle estimate off by 1.5-fold (0.17 log units), on the high side; low and high end bracket the measured number.
By their numbers in this assay, from the lowest: compounds 4, 3 and 1 (each within the scatter of the next). At a limit, above all of these: compound 2.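

In this assay, adding a hydrogen-bond donor with 3-aminophenyl does not separate this position from the other six-membered aromatic rings, since a 1.1-fold lower number from compound 3 to compound 4 (0.03 log units; within the scatter) and a 1.8-fold lower number from compound 1 to compound 4 (0.25 log units; within the scatter) both stay within the scatter. Furan-2-yl remains the one group shown that stands apart from these rings, now also in an at least 3.9-fold lower number from compound 2 to compound 4 (0.59 log units; beyond the scatter), which goes beyond the scatter. Compound 2 has a limit of the assay, not a number, so that step has only a lower bound: the limit of > 80000 nM in this assay, at which 1 of the 4 values shown sits.

On these data alone, whether a carboxylic acid or an acetamide in place of the amine on this ring would move the number beyond the scatter stays open. So does whether a saturated ring such as piperidine would behave like furan-2-yl or like the six-membered aromatic rings.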